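The source may hold more compounds than are shown below. What is called first, only, known or untested is meant among the compounds shown, and "the series" means these compounds.

Measured in a functional assay on L5178Y cells (Mus musculus) for inhibition, read by MTT assay, with a stated time of 24 h; on this read-out higher numbers stand for weaker inhibition and lower numbers for stronger inhibition:
- compound 1 `COc1ccc([C@@H]2C/C(=N\NC(=O)OCc3ccccc3)c3c(O)cc(OC)cc3O2)cc1` gives > 100000 nM as a limit
- compound 2 `COc1cc(O)c2c(c1)O[C@H](c1ccc(OCC(O)CCl)cc1)CC2=O` gives >= 11300 nM as a limit

Among the measured compounds shown here, compound 2 stands on a limit only (>= 11300 nM) and the one other value shown is a limit too.

Compound 3 (`COC(=O)C1CCN(CC(O)COc2ccc([C@@H]3CC(=O)c4c(O)cc(OC)cc4O3)cc2)CC1`) carries 4-(methoxycarbonyl)piperidin-1-yl in place of chloro on a saturated chain carbon, two bonds along the chain from an oxygen on a saturated carbon. For the measured compounds named here, no measured step covers this change. In this assay the expected step (a step that the limit leaves unreadable from compound 2 to compound 3) is modest and towards weaker inhibition, with wide uncertainty. Compound 3 is estimated at 30000 nM with a range of 8000 nM to 100000 nM as the expected span.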

Compound 3, half-maximal inhibitory concentration: >= 11300 nM
Compound 3: only a limit was reported; the forecaster's own chance of this, stated with the estimate: 45%; the middle value does not contradict the limit.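

No step can be read from compound 2 to compound 3, as both are reported only as limits: the limit of >= 11300 nM in this assay, at which 2 of the 3 values shown sit.

On these data alone, whether 4-(methoxycarbonyl)piperidin-1-yl in place of chloro changes inhibition in this assay stays open.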